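The source may hold more compounds than are shown below. What is called first, only, known or untested is meant among the compounds shown, and "the series" means these compounds.

In a functional assay on MCF7 cells (Homo sapiens) for antiproliferative activity, read by MTT assay, with a stated time of 24 h (a higher number here means a weaker inhibitor, a lower number a stronger inhibitor), compound 2 `CCCCSc1nnc(COc2cc(C)c3c(C)cc(=O)oc3c2)o1` gives > 100000 nM, which is a limit of the assay rather than a number. Compound 1 `CCCSc1nnc(COc2cc(C)c3c(C)cc(=O)oc3c2)o1` gives in this assay > 100000 nM, again a limit. Compound 3 `CCCCCSc1nnc(COc2cc(C)c3c(C)cc(=O)oc3c2)o1` gives in this assay > 100000 nM, also a limit. All three values sit at the limit of > 100000 nM in this assay, at which 3 of the 3 values shown sit. The change to compound 4 `Cc1cc(OCc2nnc(SCc3ccccc3)o2)cc2oc(=O)cc(C)c12` is phenyl in place of propyl on a saturated chain carbon bound to a sulfur. Within the data shown here, the steps that bear on a change on this chain are a step that the two limits leave unreadable from compound 1 to compound 2, a step that the two limits leave unreadable from compound 1 to compound 3 and a step that the two limits leave unreadable from compound 2 to compound 3; none of them can be read in size, so they show no direction for lengthening or altering the chain. For compound 4 no step beyond the scatter is therefore expected, and the estimated step is a step that the limit leaves unreadable from compound 2 to compound 4. Compound 4 is expected to give about 150000 nM, estimated between 30000 nM and 500000 nM, most likely again only as a limit.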

Compound 4, half-maximal inhibitory concentration: > 100000 nM
Compound 4 was reported as a limit; the forecaster's own chance of this, stated with the estimate: 80%; the middle value does not contradict the limit.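

Compound 4, like compound 1, compound 2 and compound 3, is reported only as a limit, so no step to compound 4 can be read: the limit of > 100000 nM in this assay, at which 4 of the 4 values shown sit.

The compounds shown leave open whether benzylsulfanyl and butylsulfanyl differ at all in this assay.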